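The source may hold more compounds than are shown below. What is called first, only, known or untested is meant among the compounds shown, and "the series" means these compounds.

Measured so far:
compound 1 `NC(=O)c1c(NC(=O)c2ccccc2Cl)sc2c1CCNC2` — 28700 nM
compound 2 `NC(=O)c1c(NC(=O)c2ccccc2Cl)sc2c1CCN(C(=O)Nc1ccccc1Cl)C2` — 16300 nM
compound 3 `COc1ccccc1NC(=S)N1CCc2c(sc(NC(=O)c3ccccc3Cl)c2C(N)=O)C1` — 35200 nM

In a functional assay on MKN-74 cells (Homo sapiens) for antiproliferative activity, with a stated time of 24 h (a lower number here means a stronger inhibitor, a higher number a weaker inhibitor), compound 3 gives 35200 nM, the highest number of the three; the step of a 1.2-fold higher number from compound 1 to compound 3 (0.09 log units; within the scatter) is within the scatter, whereas a 2.2-fold higher number from compound 2 to compound 3 (0.33 log units; beyond the scatter) is modest but beyond it. Compound 4 `NC(=O)c1c(NC(=O)c2ccccc2Cl)sc2c1CCN(C(=O)Nc1c(Cl)cccc1Cl)C2` differs from compound 3 by a group of 11 heavy atoms (7 carbon, 1 nitrogen, 1 oxygen, 2 chlorine; one six-membered aromatic ring of carbon only) in place of a group of 11 heavy atoms (8 carbon, 1 nitrogen, 1 oxygen, 1 sulfur; one six-membered aromatic ring of carbon only), on an amine nitrogen in a ring. For the measured compounds named here, the steps that bear on this are a 2.2-fold higher number from compound 2 to compound 3 (0.33 log units; beyond the scatter), which runs the opposite way for a related carbamoyl, and a 1.8-fold lower number from compound 1 to compound 2 (0.25 log units; within the scatter), both small. Compound 2, the nearest measured carbamoyl analogue, gave 16300 nM. Compound 4 is therefore expected to sit near that level, a step of a 2.0-fold lower number from compound 3 to compound 4 (0.29 log units; within the scatter) downward. The estimate for compound 4 is 18000 nM, within 7000 nM to 45000 nM.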

Compound 4, half-maximal inhibitory concentration: 24400 nM
Beside the measured number, compound 4's estimate is 1.4-fold (0.13 log units) below it, within the range that was stated.
By their numbers in this assay, from the lowest: compounds 2, 4, 1 and 3 (each within the scatter of the next, the first and the last beyond it).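

In this assay, chloro in place of hydrogen on an aromatic carbon gives a step that leaves compound 2 and compound 4 indistinguishable (a 1.5-fold higher number from compound 2 to compound 4 (0.18 log units; within the scatter)). On the amine nitrogen in a ring, (2,6-dichlorophenyl)carbamoyl is likewise not separated from the hydrogen of the parent (a 1.2-fold lower number from compound 1 to compound 4 (0.07 log units; within the scatter)) or from the group carried by compound 3 (a 1.4-fold lower number from compound 3 to compound 4 (0.16 log units; within the scatter)). No supporting data bear on why these numbers fall so close.

On these data alone, whether an amine or a carboxylic acid on that aromatic ring would take the number beyond the scatter remains open. The same holds for a longer chain on the ring nitrogen.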